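Dropping the Methoxy Group of Compound 2

The compounds below may be only part of what the source reports. "The series", "measured", "known", "first", "only" and "open" are said of these compounds alone.

Compound 1 `COc1cc(Br)cc(/C=C/C(=O)c2ccc(Cl)cc2)c1O` and compound 2 `COc1cc(Br)cc(/C=C/C(=O)c2ccc(C)cc2)c1O` share one core and differ only in that a methyl stands in place of a chloro on an aromatic carbon. In a functional assay on MCF7 cells (Homo sapiens) for antiproliferative activity, read by sulforhodamine B assay, with a stated time of 72 h, tested at 10 uM (on this read-out lower numbers stand for a stronger effect and higher numbers for a weaker effect at the one concentration tested), compound 1 gives 53.3%, and compound 2 gives 96.8%. Going by the values given here, the step of a number 43.5 percentage points higher from compound 1 to compound 2 (beyond the scatter) is the only measured step in this set, and compound 2 therefore holds the highest of the two numbers, with compound 1 as its sole neighbour. Compound 3 `Cc1ccc(C(=O)/C=C/c2cc(Br)ccc2O)cc1` departs from compound 2 by hydrogen in place of methoxy on an aromatic carbon. Among the compounds with values here, no measured step touches a methoxy group, so the change from chloro to methyl offers no guide to this one, and the expected step of a number 6.8 percentage points lower from compound 2 to compound 3 (within the scatter) is set at none beyond the scatter, with a wide range that leaves either direction open. Compound 3 is accordingly expected to give about 90% in this assay, between 60% and 105%.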

Compound 3, a percentage reported as activity, at one concentration (the size of the read-out at that concentration, not a potency): 27.3%
Estimate against measurement, compound 3: 62.7 percentage points above; the whole stated range lies above it.
By their numbers in this assay, from the lowest: compound 3; then compound 1; then compound 2.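

In this assay, hydrogen in place of methoxy on the aromatic carbon ortho to a hydroxy group gives a number 69.5 percentage points lower from compound 2 to compound 3 (beyond the scatter), the first step seen at this position. It shows that the read-out depends on this methoxy group as well as on the chloro or methyl site: with the methyl kept, this single change takes the series to its lowest number, with compound 3 at 27.3%. Nothing at hand explains why this methoxy group weighs so heavily on the read-out.

Going by these compounds, it remains open whether the same change would have a similar effect on compound 1, which carries chloro instead of methyl. Also open, on these data alone, is whether an ethoxy group or an amine at this position would read closer to compound 2 or to compound 3.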